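The source may report more compounds than this note shows. Statements on the series, on what has been measured and on what is new or still open speak of the compounds shown alone.

In a functional assay on the whole organism for inhibition, with Mus musculus as the target (on this read-out lower numbers stand for an effect already at smaller amounts and higher numbers for an effect only at larger amounts of compound), two compounds have been measured so far. Compound 1 (`CCCNC(=O)Nc1cccc2c1CN(C)CC2c1ccccc1`) stands at > 80 mg/kg, which is a limit of the assay and not a number. Compound 2 (`CCCCNC(=O)Nc1cccc2c1CN(C)CC2c1ccc(Cl)cc1`) gives a true number of 15 mg/kg. Compound 3 (`CN1Cc2c(NC(=O)OCc3ccccc3)cccc2C(c2ccccc2)C1`) keeps the core of compound 1 and carries benzyloxy in place of propylamino on a carbonyl carbon. Within the data shown here, no measured step between two compounds is available to gauge such a change in this assay. The expectation can therefore start only from compound 1 and its limit of > 80 mg/kg. A modest move towards smaller doses is expected, with the estimated step being an at least 1.6-fold lower number from compound 1 to compound 3 (0.20 log units; that floor lies within the scatter). The estimate for compound 3 is 50 mg/kg, with an expected range from 15 mg/kg to 150 mg/kg.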

Compound 3, dose for half-maximal effect: 16 mg/kg
For compound 3 the middle estimate is 3.1-fold (0.49 log units) above the measured one, and the stated range covers the measured number.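

With benzyloxy in place of propylamino on a carbonyl carbon, this assay shows an at least 5.0-fold lower number from compound 1 to compound 3 (0.69 log units; beyond the scatter). Among these compounds, this is the first sign that a change at this place can move the read-out on the core of compound 1. Among the compounds shown here, that core had so far given only a limit. Compound 3 gives a true number of 16 mg/kg. The size of the step can be stated only as a bound, because compound 1 stands at a limit and not at a number: the limit of > 80 mg/kg in this assay, at which 1 of the 3 values shown sits.

The compounds shown do not separate the two parts of this change, the oxygen in place of the nitrogen and the added aromatic ring. Propoxy on the same carbonyl carbon would speak to the first part and benzylamino to the second, and how either would read remains open.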